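This account rests on a few compounds, and the source may have more. Where it says the series, first, only, none or still open, it means among the compounds named here.

Among the compounds with values here, in an ADME assay on L02 cells (Homo sapiens) for cytotoxicity, read by MTT assay, with a stated time of 24 h (a higher number here means a weaker inhibitor, a lower number a stronger inhibitor), three compounds have numbers so far. Compound 1 `COc1cc(/C=C2\CN(C)C/C(=C\c3ccccc3F)C2=O)cc(OC)c1` gives 11900 nM, compound 2 `CN1C/C(=C\c2cccc([N+](=O)[O-])c2)C(=O)/C(=C/c2ccccc2F)C1` gives 13500 nM and compound 3 `COc1cc(/C=C2\CN(C)C/C(=C\c3ccc(Cl)cc3Cl)C2=O)cc(OC)c1` gives 18800 nM. Compound 3 therefore stands level with the other two, as all three values lie within the scatter of each other.

The unmeasured compound 4 `COc1cc(/C=C2\CN(C)C/C(=C\c3ccc(C#N)cc3)C2=O)cc(OC)c1` has 4-cyanophenyl in place of 2,4-dichlorophenyl on a double-bonded chain carbon bound to a double-bonded ring carbon. Within the data shown here, the only measured step at this place is a 1.6-fold higher number from compound 1 to compound 3 (0.20 log units; within the scatter), which lies within the scatter. Among the measured compounds shown here, no measured compound carries 4-cyanophenyl, so the data give no direction for this change. On that single step, no change beyond the scatter is expected in this assay. The expected step is a 1.3-fold lower number from compound 3 to compound 4 (0.13 log units; within the scatter), which is no real shift. For compound 4 the estimated value is 14000 nM, with an expected range of 7000 nM to 30000 nM.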

Compound 4, half-maximal inhibitory concentration: 14000 nM
Estimate against measurement, compound 4: no gap at the digits printed; the measured number falls inside the stated range.
By their numbers in this assay, from the lowest: compounds 1, 2, 4 and 3 (each within the scatter of the next).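

In this assay, bringing in 4-cyanophenyl on a double-bonded chain carbon bound to a double-bonded ring carbon gives a 1.3-fold lower number from compound 3 to compound 4 (0.13 log units; within the scatter) and a 1.2-fold higher number from compound 1 to compound 4 (0.07 log units; within the scatter). Within the data shown here, this place has now carried three different substituted phenyl groups on the same remaining structure, one of them with a triple bond and a hydrogen-bond acceptor, and no step among compounds 1, 3 and 4 lies beyond the scatter. No supporting measurement bears on this result.

Still open, as far as these compounds go, is whether any group at this place can move the number beyond the scatter, as only substituted phenyl groups stand there so far. A phenyl group bearing an amine or a carboxylic acid, or a longer chain in place of the phenyl group, would test how far this flat picture extends.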